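The Same Small Change Tried on a Second Core

This account rests on a few compounds, and the source may have more. Where it says the series, first, only, none or still open, it means among the compounds named here.

Of the compounds shown here, three have so far been measured in an ADME assay on microsomes from liver (Homo sapiens) for metabolic stability, tested at 2.5 uM; on this read-out higher numbers stand for fast clearance and lower numbers for slow clearance. Compound 1 `O=S(=O)(c1ccc(F)cc1)c1cnc2c(F)cccc2c1-c1cccc(F)c1` gives 1.56 mL/min in this assay. Compound 2 `COc1cccc(-c2c(S(=O)(=O)c3ccc(F)cc3)cnc3c(F)cccc23)c1` gives 2.23 mL/min. Compound 3 `O=S(=O)(c1cc(Cl)cc(Cl)c1)c1cnc2cc(F)ccc2c1-c1cccc(F)c1` gives 0.41 mL/min, the lowest of the three numbers, and its gaps to both other compounds lie beyond the scatter of repeated measurements.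

Compound 2 differs from compound 1 in one place only: methoxy in place of fluoro on an aromatic carbon. That single change produced a 1.4-fold higher number from compound 1 to compound 2 (0.16 log units; within the scatter), a step that counts as no real change.

Compound 4 `COc1cccc(-c2c(S(=O)(=O)c3cc(Cl)cc(Cl)c3)cnc3cc(F)ccc23)c1` has not yet been measured. It differs from compound 3 by methoxy in place of fluoro on an aromatic carbon. Within the data shown here, this is the same change, at the same kind of place, as the one that turns compound 1 into compound 2; it appears twice among the four compounds. The difference between the core of compound 3 and the core of compound 1 is not broken down here.

Because the earlier instance of this change gave a 1.4-fold higher number from compound 1 to compound 2 (0.16 log units; within the scatter), the expectation is that the same change on the core of compound 3 moves the number by a similarly small amount, a 1.3-fold higher number from compound 3 to compound 4 (0.13 log units; within the scatter), which stays within the scatter. Compound 4 is therefore estimated to give 0.55 mL/min, with a likely range from 0.3 mL/min to 1.1 mL/min.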

Compound 4, intrinsic clearance in a liver preparation (reported as CLH), per the amount of preparation that the assay uses: 1.51 mL/min
The estimate for compound 4 lay 2.7-fold (0.44 log units) below the measured number; measured number outside the range, above it.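

On the second core, putting 3-methoxyphenyl in place of 3-fluorophenyl gave a 3.7-fold higher number from compound 3 to compound 4 (0.57 log units; beyond the scatter) in this assay, so here the swap counts as a real change, even though the same swap on the first core did not. Setting the two steps side by side shows that the gap between them is no larger than repeated measurements could produce: the same change on two cores in this assay, a 1.4-fold higher number (0.16 log units; within the scatter) from compound 1 to compound 2 and a 3.7-fold higher number (0.57 log units; beyond the scatter) from compound 3 to compound 4, 2.6-fold (0.41 log units) apart, within the scatter of two such steps

Among these compounds, the result therefore shows that one small step on one core is a weak guide to whether the same swap will stand clear of the scatter on another core, but it does not show that the core truly alters the effect of the swap, and with only two pairs, the size of the effect on any further core remains unknown.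

The compounds shown leave open how other groups in this place, such as an amine, a carboxylic acid or a longer chain like ethoxy, would read in this assay. They also leave open whether this swap on a third core would give a step closer to the smaller one or the larger one, which is what could settle whether the two cores really behave differently.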